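The source may hold more compounds than are shown below. What is called first, only, known or untested is meant among the compounds shown, and "the series" means these compounds.

Compounds measured so far:
compound 1, `COc1ccccc1-c1cccc(S(=O)(=O)N2CCC(N3CCC(C)CC3)CC2)c1`: 0.25 h
compound 2, `Cc1cc(S(=O)(=O)N2CCC(N3CCC(C)CC3)CC2)c(Cl)cc1Cl`: 0.108 h
compound 3, `Cc1nc(Cl)sc1S(=O)(=O)N1CCC(N2CCC(C)CC2)CC1`: 0.167 h

In an ADME assay on S9 fraction from liver (Mus musculus, strain ICR/CD-1) for metabolic stability, read by LC-MS, using NADPH, with a stated time of 5 min, tested at 2 uM (on this read-out higher numbers stand for a longer-lived compound and lower numbers for a shorter-lived compound), compound 1 gives the largest of the three numbers. Compound 3 lies within the usual scatter of compound 1, whereas compound 2 falls beyond it, so the only separation that holds is between compound 1 and compound 2.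

Compound 4, `Cc1cc(C)cc(-c2cccc(S(=O)(=O)N3CCC(N4CCC(C)CC4)CC3)c2)c1`, is not yet measured. It differs from compound 1 in one place: 3,5-dimethylphenyl in place of 2-methoxyphenyl on an aromatic carbon. For the measured compounds named here, with no measured pair showing this kind of change, the step from compound 1 to compound 4 is expected to be small, in either direction, and not beyond the scatter; the expected step is a 1.3-fold lower number from compound 1 to compound 4 (0.10 log units; within the scatter). For compound 4 in this assay the estimate is 0.2 h, with a range from 0.08 h to 0.5 h.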

Compound 4, half-life: > 4 h
Compound 4: no number, only a limit; the forecaster's own chance of this, stated with the estimate: 5%; middle value at least 20-fold (1.30 log units) from the limit.
By their numbers in this assay, from the lowest: compounds 2, 3 and 1 (each within the scatter of the next, the first and the last beyond it). At a limit, above all of these: compound 4.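

The earlier compounds shown here offered no step in one place, and this pair gives the first: in this assay, 3,5-dimethylphenyl in place of 2-methoxyphenyl on an aromatic carbon, meta to a large group, gives an at least 16-fold higher number from compound 1 to compound 4 (1.20 log units; beyond the scatter). The two groups hold the same count of heavy atoms and one six-membered aromatic ring of carbon only, yet the step is large. The value of compound 4 is a limit and not a number: the limit of > 4 h in this assay, at which 1 of the 4 values shown sits.

The compounds shown do not separate the loss of the methoxy group from the gain of the two methyl groups. From the compounds shown here alone, how a phenyl ring with a single methyl group, or one carrying an amine or a carboxylic acid, would behave at this place remains open.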